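The source may hold more compounds than are shown below. What is called first, only, known or untested is meant among the compounds shown, and "the series" means these compounds.

Working notes on the series, read in a functional assay on MGC-803 cells (Homo sapiens) for cytotoxicity, read by MTT assay, with a stated time of 48 h; on this read-out lower numbers stand for stronger inhibition and higher numbers for weaker inhibition. Compound 1 (`CCC(=O)N1N=C(c2cc3ccccc3oc2=O)CC1c1ccccc1`) gives 5300 nM, and compound 2 (`CNCC(=O)N1N=C(c2cc3ccccc3oc2=O)CC1c1ccccc1`) gives 12800 nM. Among the measured compounds shown here, the only measured step, a 2.4-fold higher number from compound 1 to compound 2 (0.38 log units; beyond the scatter), is modest and runs toward weaker inhibition. For the measured compounds named here, compound 3 (`O=C(CNC1CC1)N1N=C(c2cc3ccccc3oc2=O)CC1c1ccccc1`) has no number: it is recorded as "not active" (no number reported), so no step can be calculated from it.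

The next compound, compound 4 (`CC(C)(C)NCC(=O)N1N=C(c2cc3ccccc3oc2=O)CC1c1ccccc1`), has not been measured. The change from compound 3 is tert-butyl in place of cyclopropyl on an amine nitrogen. Going by the values given here, no measured step covers this exchange, and the one step available concerns a different change, so it bears only indirectly. It does show that compound 2, with methyl on the amine nitrogen, sits at 12800 nM, on the weak side of compound 1. Compound 3, with cyclopropyl on that nitrogen, reads "not active" (no number reported). Neither compound points toward a lower number in this assay.

The expectation is therefore a modest step toward a higher number than that of compound 2 at 12800 nM, with no gain in inhibition. A report without a number is also quite possible. For compound 4 the estimated value is 20000 nM, with an expected range of 8000 nM to 50000 nM.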

Compound 4, half-maximal inhibitory concentration: 15400 nM
Beside the measured number, compound 4's estimate is 1.3-fold (0.11 log units) above it, and the stated range covers the measured number.
By their numbers in this assay, from the lowest: compound 1; then compounds 2 and 4 (each within the scatter of the next).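

In this assay compound 3 is recorded as "not active" while compound 4 gives 15400 nM. On an amine nitrogen, cyclopropyl thus goes with a record without a number and tert-butyl with a number, although that step itself cannot be read. The size of the substituent on this nitrogen does not separate the two numerical amines, with a 1.2-fold higher number from compound 2 to compound 4 (0.08 log units; within the scatter), and methyl and tert-butyl therefore read alike here, while the cyclopropyl of compound 3 stands apart from both. With a 2.9-fold higher number from compound 1 to compound 4 (0.46 log units; beyond the scatter), the (tert-butyl)amino exchange on the saturated chain carbon bound to the carbonyl carbon stays on the weak side of compound 1, as the methylamino exchange does with a 2.4-fold higher number from compound 1 to compound 2 (0.38 log units; beyond the scatter).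

No measurement at hand bears on why these compounds read as they do. Still open, as far as these compounds go, is whether an unsubstituted amino group, an isopropylamino group or a ring amine such as morpholine at this position would fall with methyl and tert-butyl, read like cyclopropyl or give a number lower than that of compound 1.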